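A Carboxy Group in Place of a Cyano Group

This account rests on a few compounds, and the source may have more. Where it says the series, first, only, none or still open, it means among the compounds named here.

In an assay on isolated protein for inhibition of Rho-associated protein kinase 2 (Homo sapiens), read by scintillation counting, radiometric assay and 33P incorporation, with a stated time of 40 min, in the presence of a further agent that is not named here (on this read-out higher numbers stand for weaker inhibition and lower numbers for stronger inhibition), three compounds have been measured:
compound 1, `Cc1c(OCC(=O)Nc2cccc(NC(=O)c3ccc(N(C)C)cc3)c2)ccc2c(=O)ccoc12`, 4160 nM;
compound 2, `N#Cc1ccc(C(=O)Nc2cccc(NC(=O)COc3ccc4c(=O)ccoc4c3)c2)cc1`, 15 nM;
compound 3, `CC(C)(C)c1ccc(S(=O)(=O)Nc2cccc(NC(=O)COc3ccc4c(=O)ccoc4c3)c2)cc1`, 899 nM.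

Compound 2 has the lowest number of the three, and compounds 1 and 3 both lie beyond the usual scatter above it, so compound 2 is the strongest inhibitor in this set. Compound 4, `O=C(COc1ccc2c(=O)ccoc2c1)Nc1cccc(NC(=O)c2ccc(C(=O)O)cc2)c1`, has not yet been measured. It differs from compound 2 in one place: carboxy in place of cyano on an aromatic carbon. Within the data shown here, no pair of measured compounds differing in a single group is available, so the effect of this exchange cannot be read from the data. A moderate weakening, beyond the scatter, is expected, as an 8.0-fold higher number from compound 2 to compound 4 (0.90 log units; beyond the scatter). For compound 4 the value in this assay is estimated at 120 nM, within a range from 20 nM to 800 nM.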

Compound 4, half-maximal inhibitory concentration: 2030 nM
The estimate for compound 4 lay 17-fold (1.23 log units) below the measured number, outside the stated range (above it).
By their numbers in this assay, from the lowest: compound 2; then compound 3; then compound 4; then compound 1.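

In this assay, among these compounds, carboxy in place of cyano on this aromatic carbon, para to a large group, gives a 140-fold higher number from compound 2 to compound 4 (2.13 log units; beyond the scatter) as the only comparison here that differs in one place. This shows that the position is sensitive to what it carries, since a single exchange on the 4-cyanophenyl moves the number this far. Nothing in the available data explains this loss.

Going by these compounds, it remains open how other groups at this place would compare with cyano and carboxy. A methyl ester, a primary amide or an amine there would show whether the loss is specific to carboxy.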